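This account rests on a few compounds, and the source may have more. Where it says the series, first, only, none or still open, it means among the compounds named here.

Compound 1 `COc1cc(/C=C/C(C)=O)ccc1OCc1cn(-c2ccccc2CO)nn1`: 65800 nM
Compound 2 `COc1cc(/C=C/C(C)=O)ccc1OCc1cn(-c2c(Cl)cccc2Cl)nn1`: 26600 nM
Compound 3 `COc1cc(/C=C/C(C)=O)ccc1OCc1cn(-c2ccc(C=O)cc2)nn1`: 86400 nM

In a functional assay on MCF7 cells (Homo sapiens) for antiproliferative activity, read by MTT assay, with a stated time of 48 h (on this read-out lower numbers stand for stronger inhibition and higher numbers for weaker inhibition), compound 3 gives 86400 nM, at the weak end of this small set alongside compound 1, as shown by a 1.3-fold higher number from compound 1 to compound 3 (0.12 log units; within the scatter). Compound 4 `COc1cc(/C=C/C(C)=O)ccc1OCc1cn(-c2cc(F)cc(Br)c2)nn1` carries 3-bromo-5-fluorophenyl in place of 4-formylphenyl on an aromatic nitrogen. For the measured compounds named here, compound 2 is the only measured compound with halogen on that ring, and it stands apart: a 3.2-fold higher number from compound 2 to compound 3 (0.51 log units; beyond the scatter), and a 2.5-fold lower number from compound 1 to compound 2 (0.39 log units; beyond the scatter). Three compounds cannot establish a rule, but a modest move to a lower number is expected in this assay. The expected change is a 2.5-fold lower number from compound 3 to compound 4 (0.39 log units; beyond the scatter). For compound 4 the estimated value is 35000 nM, with an expected range from 14000 nM to 85000 nM.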

Compound 4, half-maximal inhibitory concentration: 65500 nM
Beside the measured number, compound 4's estimate is 1.9-fold (0.27 log units) below it; the measured number falls inside the stated range.
By their numbers in this assay, from the lowest: compound 2; then compounds 4, 1 and 3 (each within the scatter of the next).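

In this assay, a halogen on this ring does not by itself go with the lower number: a 1.3-fold lower number from compound 3 to compound 4 (0.12 log units; within the scatter) and a 1.0-fold lower number from compound 1 to compound 4 (0.00 log units; within the scatter), whereas a 2.5-fold higher number from compound 2 to compound 4 (0.39 log units; beyond the scatter). Of the two halogen-bearing rings, only the 2,6-dichlorophenyl of compound 2 stands apart from the others. No measured evidence accounts for this gap.

Compounds 2 and 4 differ in both their halogens and where these sit, so the compounds shown cannot separate those two changes. From the compounds shown here alone, how a phenyl ring carrying an amine or a carboxylic acid would behave also stays open.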